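Replacing Trifluoromethyl with Tert-Butyl on a Hydroxamic Acid

This account rests on a few compounds, and the source may have more. Where it says the series, first, only, none or still open, it means among the compounds named here.

Measured so far:
- compound 1, `O=C(NO)c1ccc(N(Cc2ccc(C(F)(F)F)cc2)C(=O)CN(Cc2ccccc2C(F)(F)F)S(=O)(=O)c2ccc(F)c(F)c2)cc1`: 188 nM
- compound 2, `O=C(NO)c1ccc(N(Cc2ccc(C(F)(F)F)cc2)C(=O)CN(Cc2ccccc2C(F)(F)F)S(=O)(=O)c2ccc(F)cc2)cc1`: 93 nM

Both values come from an assay on Sf9 cells for inhibition of protein deacetylase HDAC6 (Homo sapiens), read by mobility shift assay; on this read-out lower numbers stand for stronger inhibition and higher numbers for weaker inhibition. Compound 1 gives the higher of the two numbers; its nearest neighbour is compound 2, reached by a 2.0-fold lower number from compound 1 to compound 2 (0.31 log units; beyond the scatter), which is hydrogen in place of fluoro on an aromatic carbon.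

Compound 3, `CC(C)(C)c1ccc(CN(C(=O)CN(Cc2ccccc2C(F)(F)F)S(=O)(=O)c2ccc(F)c(F)c2)c2ccc(C(=O)NO)cc2)cc1`, has not yet been measured. It differs from compound 1 by tert-butyl in place of trifluoromethyl on an aromatic carbon. Among the measured compounds shown here, the only measured step, from compound 1 to compound 2, changes a different part of the shared core, so no measured step speaks directly to this trifluoromethyl-to-tert-butyl exchange. With nothing to guide the direction, the expectation is a step of no more than modest size, likely within the scatter, in either direction.

Compound 3 is therefore expected to give about 190 nM, with a range from 60 nM to 600 nM. This estimate means a step of a 1.0-fold higher number from compound 1 to compound 3 (0.00 log units; within the scatter), which is expected to stay within the scatter.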

Compound 3, half-maximal inhibitory concentration: 362 nM
Estimate against measurement, compound 3: 1.9-fold (0.28 log units) below; the measured number falls inside the stated range.
By their numbers in this assay, from the lowest: compound 2; then compounds 1 and 3 (each within the scatter of the next).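

Among the compounds shown here, exchanging 4-(trifluoromethyl)benzyl for 4-(tert-butyl)benzyl gives the first reading at this position in this assay (a 1.9-fold higher number from compound 1 to compound 3 (0.28 log units; within the scatter)), and compound 1 and compound 3 cannot be told apart on this read-out. The earlier step changed a fluoro elsewhere on the shared core, whereas this one shows that, at this place on the ring, para to a large group, a group made only of carbon and hydrogen can stand where a fluorine-bearing group stood without a difference that rises above the scatter of repeated measurements. Neither group adds a ring, a hydrogen-bond donor or a hydrogen-bond acceptor, and nothing measured here explains why the two read so alike.

Whether this position accepts groups of a different kind, such as an amine, a carboxylic acid or a longer chain, stays open, as all that is shown here is one pair of groups with the same count of heavy atoms. Also open, on these data alone, is whether the fluoro-to-hydrogen change (a 2.0-fold lower number from compound 1 to compound 2 (0.31 log units; beyond the scatter)) would give a similar step on a core carrying tert-butyl.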